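The compounds below may be only part of what the source reports. "The series", "measured", "known", "first", "only" and "open" are said of these compounds alone.

Measured so far in a functional assay on KB cells (Homo sapiens) for cytotoxicity, read by resazurin assay, with a stated time of 3 days; a lower number here means a stronger inhibitor, a higher number a weaker inhibitor:
- compound 1 `COC1=C(CC(C)(C)CNC(=O)c2ccccc2)C(=O)c2ccccc2C1=O`: 117000 nM
- compound 2 `COC1=C(CC(C)(C)CNC(=O)c2ccc3ccccc3c2)C(=O)c2ccccc2C1=O`: 34100 nM

Among the compounds with values here, compound 2 has the lower of the two numbers, and compound 1 is its only neighbour on the scale. The next structure is compound 3 `COC1=C(CC(C)(C)CNC(=O)c2cc(OC)ccc2OC)C(=O)c2ccccc2C1=O`, which has 2,5-dimethoxyphenyl in place of naphthalen-2-yl on a carbonyl carbon. Within the data shown here, one measured step bears on this change, at the same place: a 3.4-fold lower number from compound 1 to compound 2 (0.54 log units; beyond the scatter), with naphthalen-2-yl in place of phenyl. That step is modest but beyond the scatter. Among the measured compounds shown here, no measured compound carries the 2,5-dimethoxyphenyl group, so the read-across is loose. Losing naphthalen-2-yl is expected to give back part of that step, which means a modest move to a higher number in this assay. The expected step is a 2.1-fold higher number from compound 2 to compound 3 (0.31 log units; beyond the scatter). For compound 3 the estimated value is 70000 nM, with an expected range of 25000 nM to 170000 nM.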

Compound 3, half-maximal inhibitory concentration: 34300 nM
Beside the measured number, compound 3's estimate is 2.0-fold (0.31 log units) above it; the measured number falls inside the stated range.
By their numbers in this assay, from the lowest: compounds 2 and 3 (each within the scatter of the next); then compound 1.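

Working notes on the carbonyl-carbon position in this assay: replacing naphthalen-2-yl with 2,5-dimethoxyphenyl gives a 1.0-fold higher number from compound 2 to compound 3 (0.00 log units; within the scatter), so the second aromatic ring of naphthalen-2-yl is not needed to hold the number reached by compound 2. Against the plain phenyl, the dimethoxy group gives a 3.4-fold lower number from compound 1 to compound 3 (0.53 log units; beyond the scatter), which means that two different groups at this position now each stand beyond the scatter from compound 1. No supporting measurement is available to account for this result.

On these data alone, whether a phenyl carrying a single methoxy group would match 2,5-dimethoxyphenyl remains open. Also open, as far as these compounds go, is what an amine or a carboxylic acid on that aromatic ring would do to the number in this assay.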